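Moving from the free thiourea to its 4-fluorophenyl analogue

This account rests on a few compounds, and the source may have more. Where it says the series, first, only, none or still open, it means among the compounds named here.

Measured compounds:
- compound 1, `O=c1ccc(-c2ccccc2)nn1CCCC/N=C(\S)Nc1cccc(F)c1`: 30.4%
- compound 2, `N/C(S)=N/CCCCn1nc(-c2ccccc2)ccc1=O`: 72%

Of the compounds shown here, two have been measured in a functional assay on the whole organism with Rattus norvegicus as the target, at a dose of 100 mg/kg; a higher number here means more inhibition at the dose given (going by the name of the read-out), a lower number less inhibition. Among the compounds with values here, compound 2 stands highest of the two numbers, and its nearest neighbour is compound 1, which lies a large distance lower; the one step recorded between them, a number 41.6 percentage points higher from compound 1 to compound 2 (beyond the scatter), is beyond the scatter.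

The unmeasured compound 3, `O=c1ccc(-c2ccccc2)nn1CCCC/N=C(\S)Nc1ccc(F)cc1`, differs from compound 2 by 4-fluorophenyl in place of hydrogen on an amine nitrogen. This is the mirror image of the measured step: where compound 1 carried a 3-fluorophenyl group on the amine nitrogen and compound 2 carries only hydrogen, compound 3 again carries a fluorophenyl group there. That single step, a number 41.6 percentage points higher from compound 1 to compound 2 (beyond the scatter), bears directly on the expectation, and since it ran upward on removing the aryl group, putting an aryl group back is expected to run downward by a comparable amount. Compound 3 is therefore expected to show a number 37 percentage points lower from compound 2 to compound 3 (beyond the scatter). The estimate for compound 3 is 35%, with a range from 15% to 60%.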

Compound 3, a percentage reported as inhibition, in the whole organism at one dose (the size of the read-out at that dose, not a potency): 45.6%
Compound 3: the middle estimate sits 10.6 percentage points below what was measured, within the range that was stated.
By their numbers in this assay, from the lowest: compound 1; then compound 3; then compound 2.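

In this assay, compound 3 shows that the loss seen with compound 1 is not confined to the 3-fluorophenyl group: a second fluorophenyl group on the amine nitrogen also lowers the number (a number 26.4 percentage points lower from compound 2 to compound 3 (beyond the scatter)), leaving compound 2, with hydrogen at this place, above both aryl compounds. The new comparison also shows that the two fluorophenyl groups are not interchangeable, since exchanging one for the other, with the rest of the structure unchanged, gives a step beyond the scatter (a number 15.2 percentage points higher from compound 1 to compound 3 (beyond the scatter)), so the size of the loss depends on which fluorophenyl group is attached. Nothing available gives a reason for either step.

On these data alone, what remains open is whether this order extends to other groups on the amine nitrogen, such as an unsubstituted phenyl, a 2-fluorophenyl, a 4-chlorophenyl, a benzyl or a small methyl group, and whether any of them would come close to hydrogen. The compounds shown also leave open how a shorter or longer chain, or a urea carbonyl in place of the sulfur-bearing carbon, would behave in this assay.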